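Shortening the Amide Substituent: From Compound 3 to Compound 4

The source may hold more compounds than are shown below. What is called first, only, known or untested is meant among the compounds shown, and "the series" means these compounds.

Compound 1 `COC(=O)C(=O)Nc1cccc(C(=O)/C=C/c2ccc(O)c(OC)c2)c1` gives 20% in a functional assay on HUVEC cells (Homo sapiens) for inhibition, tested at 5 ug/mL; on this read-out higher numbers stand for a stronger effect at the one concentration tested and lower numbers for a weaker effect.
Compound 2 `CCCC(=O)Nc1cccc(C(=O)/C=C/c2ccc(O)c(OC)c2)c1` gives 57% in this assay.
Compound 3 `CCOC(=O)C(=O)Nc1cccc(C(=O)/C=C/c2ccc(O)c(OC)c2)c1` gives 45% in this assay.

Among these three numbers compound 3 stands second highest. Its nearest neighbour is compound 2, seen in a number 12 percentage points lower from compound 2 to compound 3 (beyond the scatter), and its furthest is compound 1, seen in a number 25 percentage points higher from compound 1 to compound 3 (beyond the scatter).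

Compound 4 `COc1cc(/C=C/C(=O)c2cccc(NC(C)=O)c2)ccc1O` differs from compound 3 in one place:

methyl in place of ethoxycarbonyl on a carbonyl carbon

Within the data shown here, two measured steps bear on this change, since both swap an ester-bearing group against a plain alkyl chain on the same carbonyl carbon. Propyl in place of methoxycarbonyl gave a number 37 percentage points higher from compound 1 to compound 2 (beyond the scatter), a large rise. The reverse direction, ethoxycarbonyl in place of propyl, gave a number 12 percentage points lower from compound 2 to compound 3 (beyond the scatter), a modest fall. Both point the same way: an alkyl group on that carbonyl carbon sits higher than an ester. Methyl is shorter than propyl, and no measured step shows how much chain length itself matters, so the size of the rise is uncertain, but a step upward beyond the scatter, of modest size, is the natural expectation.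

Compound 4 is therefore estimated to give 55%, with a likely range from 38% to 72%. The expected step is a number 10 percentage points higher from compound 3 to compound 4 (within the scatter).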

Compound 4, a percentage reported as inhibition, at one concentration (the size of the read-out at that concentration, not a potency): 15%
Compound 4: middle estimate off by 40 percentage points, on the high side; measured number outside the range, below it.
By their numbers in this assay, from the lowest: compounds 4 and 1 (each within the scatter of the next); then compound 3; then compound 2.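

In this assay, methyl in place of ethoxycarbonyl on the carbonyl carbon gave a number 30 percentage points lower from compound 3 to compound 4 (beyond the scatter), so an alkyl group at this place does not by itself sit higher than an ester, as the steps among compound 1, compound 2 and compound 3 had suggested. The length of the alkyl chain now proves to matter: hydrogen in place of ethyl on the saturated chain carbon bound to the carbonyl carbon, which shortens propyl to methyl, gave a number 42 percentage points lower from compound 2 to compound 4 (beyond the scatter). Methyl in place of methoxycarbonyl gave a number 5 percentage points lower from compound 1 to compound 4 (within the scatter), so these two groups cannot be told apart at this position, and the earlier rise from ester to alkyl holds for propyl but not for methyl.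

An ethyl chain would show whether the number climbs gradually from methyl to propyl or jumps, and a butyl or longer chain would show whether the climb continues past propyl. How an amine or a carboxylic acid at the end of the chain would compare also remains open, and nothing measured here explains why these steps take the sizes they do.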